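The compounds below may be only part of what the source reports. "The series", "measured", "known", "first", "only" and "open" are said of these compounds alone.

Three related compounds have been tested in a functional assay on the whole organism (strain Wistar) for inhibition, with Rattus norvegicus as the target, with stated times of 30 min and 3 h, at a dose of 20 mg/kg by the oral route; a lower number here means less inhibition, a higher number more inhibition at the dose given (going by the name of the read-out). Compound 1 `O=C(CCc1nnc(-c2ccc(Cl)cc2)o1)c1ccccc1` serves as the starting point; in this assay compound 1 gives 81.5%. Compound 2 `O=C(CCc1nnc(-c2ccc([N+](=O)[O-])cc2)o1)c1ccccc1` carries one change on the same core, (nitro in place of chloro on an aromatic carbon); in this assay compound 2 gives 62.7%, which is a number 18.8 percentage points lower from compound 1 to compound 2 (beyond the scatter). Compound 3 `Cc1ccc(C(=O)CCc2nnc(-c3ccc(Cl)cc3)o2)cc1` differs from compound 1 in a different place, (methyl in place of hydrogen on an aromatic carbon); in this assay compound 3 gives 81.5%, so no change at the digits printed from compound 1 to compound 3 (within the scatter). For the measured compounds named here, compound 1 and compound 3 thus stand level at the highest of the three numbers, and compound 2 is the one furthest from compound 3.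

Compound 4 `Cc1ccc(C(=O)CCc2nnc(-c3ccc([N+](=O)[O-])cc3)o2)cc1` has not yet been measured. It differs from compound 3 by nitro in place of chloro on an aromatic carbon. This is the same change that turned compound 1 into compound 2, and the place is described in the same words in both cases, so it is the same change, occurring twice among these four compounds. The core of compound 3 differs from the core of compound 1 only by the methyl already described.

The expected step is a number 18.5 percentage points lower from compound 3 to compound 4 (beyond the scatter), because a number 18.8 percentage points lower from compound 1 to compound 2 (beyond the scatter) was the outcome of the same change on a core that behaves like the core of compound 3. Compound 4 is therefore estimated to give about 63%, with a likely range from 48% to 78%.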

Compound 4, a percentage reported as inhibition, in the whole organism at one dose (the size of the read-out at that dose, not a potency): 60.5%
The estimate for compound 4 lay 2.5 percentage points above the measured number; low and high end bracket the measured number.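

In this assay, nitro in place of chloro costs about the same on both cores. The new step is a number 21 percentage points lower from compound 3 to compound 4 (beyond the scatter), and it sits close to the earlier one: the same change on two cores in this assay, a number 18.8 percentage points lower (beyond the scatter) from compound 1 to compound 2 and a number 21 percentage points lower (beyond the scatter) from compound 3 to compound 4, 2.2 percentage points apart, within the scatter of two such steps. Read the other way, methyl in place of hydrogen on an aromatic carbon makes no real difference on the nitro compounds either, with a number 2.2 percentage points lower from compound 2 to compound 4 (within the scatter), as was already seen on the chloro compounds: the same change on two cores in this assay, no change at the digits printed (within the scatter) from compound 1 to compound 3 and a number 2.2 percentage points lower (within the scatter) from compound 2 to compound 4, 2.2 percentage points apart, within the scatter of two such steps. So within these four compounds the two changes act independently, and each one's step can be carried from one core to the other, but the two cores differ only by that methyl, so this says nothing about cores that differ more widely, and a reading at a single dose is not a potency and gives no reason for the drop.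

The compounds shown leave open how other groups would read in the place of chloro and nitro, such as an amine or a carboxylic acid, and whether the nitro step would keep its size with them. They also leave open what a longer chain between the carbonyl and the shared ring system's oxadiazole-free remainder would do, or a methoxy group in place of the methyl.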